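This account rests on a few compounds, and the source may have more. Where it says the series, first, only, none or still open, it means among the compounds named here.

In an assay on HEK293 cells for displacement of a labelled ligand from 5-hydroxytryptamine receptor 4 (Homo sapiens), read by scintillation counting (a lower number here means a stronger inhibitor, a higher number a weaker inhibitor), compound 3 `COc1cc(N)c(Cl)cc1C(=O)NC1CCN(CCCCCN2CCCCC2)CC1` gives 10 nM, the lowest of the three numbers measured. Compound 1 `CCCCCN1CCC(NC(=O)c2cc(Cl)c(N)cc2OC)CC1` gives 100 nM, and compound 2 `COc1cc(N)c(Cl)cc1C(=O)NC1CCN(CCN2CCCCC2)CC1` gives 251 nM. Compound 4 `COc1cc(N)c(Cl)cc1C(=O)NC1CCN(CCN2CCN(S(C)(=O)=O)CC2)CC1` differs from compound 3 in one place: 4-(methylsulfonyl)piperazin-1-yl in place of 3-(piperidin-1-yl)propyl on a saturated chain carbon, two bonds along the chain from an amine nitrogen in a ring. Within the data shown here, two measured steps bear on this change. Read in reverse, a 25-fold lower number from compound 2 to compound 3 (1.40 log units; beyond the scatter) shows how much is lost when the long link shrinks to a ring set two bonds from the ring amine, and a 2.5-fold higher number from compound 1 to compound 2 (0.40 log units; beyond the scatter) shows that such a ring gave a weaker result than the plain propyl chain. Compound 4 keeps that short link, so it is expected to be clearly weaker, a 40-fold higher number from compound 3 to compound 4 (1.60 log units; beyond the scatter). For compound 4 the estimated value in this assay is 400 nM, with a range from 100 nM to 2000 nM.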

Compound 4, inhibition constant: 126 nM
Estimate against measurement, compound 4: 3.2-fold (0.50 log units) above; the range from low to high includes it.
By their numbers in this assay, from the lowest: compound 3; then compounds 1, 4 and 2 (each within the scatter of the next, the first and the last beyond it).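

In this assay, 4-(methylsulfonyl)piperazin-1-yl in place of 3-(piperidin-1-yl)propyl proves costly, a 13-fold higher number from compound 3 to compound 4 (1.10 log units; beyond the scatter). Two other steps, a 2.0-fold lower number from compound 2 to compound 4 (0.30 log units; within the scatter) and a 1.3-fold higher number from compound 1 to compound 4 (0.10 log units; within the scatter), both lie within the scatter, so at this place the new group cannot be told apart from piperidin-1-yl or propyl. Nothing available explains this result. Going by these compounds, it remains open whether a longer chain ending in 4-(methylsulfonyl)piperazin-1-yl would match compound 3, and what a morpholine ring would give at this place.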